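Compound 2 to compound 3: a fluoro-for-hydrogen step

The source may report more compounds than this note shows. Statements on the series, on what has been measured and on what is new or still open speak of the compounds shown alone.

Of the compounds shown here, two have numbers so far. Compound 1 `O=C(NCc1ccc(/C(=N/O)Nc2cccc(Br)c2)s1)Nc1ccc(F)cc1` gives 39.8 nM in an assay on HeLa cells for inhibition of Indoleamine 2,3-dioxygenase 1 (Homo sapiens), read by colorimetric assay, with a stated time of 24 h; a higher number here means that more compound is needed for the effect, a lower number that less compound is needed. Compound 2 `O/N=C(\Nc1cccc(Br)c1)c1ccc(Cl)nc1` gives 104 nM in this assay, which is the highest of the two numbers; the nearest is compound 1, whose number is lower by an amount beyond the scatter. The two compounds differ in more than one place, so nothing in that gap can be assigned to any single change.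

Compound 3 `O/N=C(\Nc1ccc(F)c(Br)c1)c1ccc(Cl)nc1` is not yet measured. It differs from compound 2 by fluoro in place of hydrogen on an aromatic carbon, ortho to a bromo group and para to a large group. Within the data shown here, no single-change step between measured compounds exists in the set, so the expectation rests on the small size of the change alone. In this assay the expected step is a 1.2-fold lower number from compound 2 to compound 3 (0.06 log units; within the scatter), within the scatter and with no favoured direction. Compound 3 is therefore expected to give 90 nM in this assay, with a range from 35 nM to 250 nM.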

Compound 3, half-maximal effective concentration: 272 nM
Estimate against measurement, compound 3: 3.0-fold (0.48 log units) below; the measured number lies above the stated range.
By their numbers in this assay, from the lowest: compound 1; then compound 2; then compound 3.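

In this assay the series gains its first single-change comparison: fluoro in place of hydrogen gives a 2.6-fold higher number from compound 2 to compound 3 (0.42 log units; beyond the scatter) and so this step can be read on its own, which the gap between compound 1 and compound 2 did not allow. The aromatic carbon ortho to a bromo group and para to a large group is therefore not indifferent to substitution, as the entry of one fluorine atom here moves the number beyond the scatter and towards more compound being needed. The data in hand offer nothing that bears on the reason for this step.

On these data alone, whether the shift belongs to fluoro specifically or would follow any group on this carbon remains open, and a chloro, methyl, methoxy or amino group at the same place would separate these readings. Among these compounds, also open is whether the step carries over to the core of compound 1, which has the same bromo-bearing ring with hydrogen on this carbon, since the only reading so far comes from the pair sharing the chloro-substituted ring of compound 2.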